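Acetyl in place of (2-chlorophenyl)carbonyl: an untried step

This account rests on a few compounds, and the source may have more. Where it says the series, first, only, none or still open, it means among the compounds named here.

compound 1 `O=C(Nc1cc(C(F)(F)F)cc(C(F)(F)F)c1)C1CCc2ccccc2N1C(=O)c1cccc(Cl)c1`: 1190 nM in a functional assay on MDA-MB-231 cells (Homo sapiens) for cytotoxicity, read by sulforhodamine B assay, with a stated time of 72 h; a higher number here means a weaker inhibitor of growth, a lower number a stronger inhibitor of growth
compound 2 `O=C(Nc1ccccc1C(F)(F)F)C1CCc2ccccc2N1C(=O)c1ccccc1Cl`: 2530 nM
compound 3 `O=C(Nc1ccccc1O)C1CCc2ccccc2N1C(=O)c1ccccc1Cl`: 47400 nM

Among these three numbers compound 2 stands second highest in this assay: compound 1 shows a lower number, and the only single-point step measured, a 19-fold higher number from compound 2 to compound 3 (1.27 log units; beyond the scatter), is a large rise. Compound 4 `CC(=O)N1c2ccccc2CCC1C(=O)Nc1ccccc1C(F)(F)F` differs from compound 2 at a different place: methyl in place of 2-chlorophenyl on a carbonyl carbon. For the measured compounds named here, no measured step touches this carbonyl, so the known step gives no direct guide; it only shows that this series can move strongly on one change. Since a whole aromatic ring leaves, a rise beyond the scatter is expected, a 3.6-fold higher number from compound 2 to compound 4 (0.55 log units; beyond the scatter), with wide uncertainty. Compound 4 is estimated at 9000 nM, within 2500 nM to 35000 nM.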

Compound 4, concentration for 50% growth inhibition: > 80000 nM
Compound 4: no number, only a limit; the forecaster's own chance of this, stated with the estimate: 10%; at least 8.8-fold (0.94 log units) between middle value and limit.
By their numbers in this assay, from the lowest: compound 1; then compound 2; then compound 3. At a limit, above all of these: compound 4.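

For the compounds shown here, on this carbonyl carbon, which no earlier step had touched, methyl in place of 2-chlorophenyl gives an at least 31-fold higher number from compound 2 to compound 4 (1.49 log units; beyond the scatter) and so is a large loss, larger than the hydroxy change elsewhere on the molecule appeared to set as the range of this series. For compound 4 the result is a limit and not a number: the limit of > 80000 nM in this assay, at which 1 of the 4 values shown sits. Going by these compounds, the true size of this step in this assay therefore remains unknown.

On these data alone, whether an unsubstituted phenyl, a cyclohexyl or a benzyl on this carbonyl would keep growth inhibition remains open. So does whether a longer chain such as butyl would behave like methyl.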